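From ethylsulfanyl to methoxy in compound 3

The source may report more compounds than this note shows. Statements on the series, on what has been measured and on what is new or still open speak of the compounds shown alone.

In a functional assay on HL-60 cells (Homo sapiens) for inhibition, read by resazurin assay, with a stated time of 72 h (on this read-out higher numbers stand for weaker inhibition and lower numbers for stronger inhibition), compound 1 `CCSc1ccc(C2C(O)C(=O)N2c2cc(OC)c(OC)c(OC)c2)cc1` gives 16 nM and compound 2 `CCSc1ccc(C2CC(=O)N2c2cc(OC)c(OC)c(OC)c2)cc1` gives 204 nM as the higher of the two numbers, so compound 2 is the weaker inhibitor of this pair. Compound 3 `COc1ccc(C2CC(=O)N2c2cc(OC)c(OC)c(OC)c2)cc1` differs from compound 2 by methoxy in place of ethylsulfanyl on an aromatic carbon, para to a large group: methoxy in place of ethylsulfanyl on an aromatic carbon is the full count of that change. Among the measured compounds shown here, the one measured step, a 13-fold higher number from compound 1 to compound 2 (1.11 log units; beyond the scatter) is large, but it is hydrogen in place of hydroxy on a saturated ring carbon, so it bears only indirectly on this change. For the measured compounds named here, no measured step covers this aromatic carbon, so no step beyond the scatter is expected in this assay and the direction stays open. The estimated step is a 1.5-fold higher number from compound 2 to compound 3 (0.17 log units; within the scatter) with wide uncertainty. For compound 3 the estimate is 300 nM with an expected range of 80 nM to 1200 nM in this read-out.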

Compound 3, half-maximal inhibitory concentration: 76 nM
For compound 3 the middle estimate is 3.9-fold (0.60 log units) above the measured one, outside the stated range (below it).
By their numbers in this assay, from the lowest: compound 1; then compound 3; then compound 2.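

In this assay, this aromatic carbon, para to a large group, now has a measured step, a 2.7-fold lower number from compound 2 to compound 3 (0.43 log units; beyond the scatter), so the change from ethylsulfanyl to methoxy shifts inhibition and the ethylsulfanyl group is not required for the stronger result of this pair. Among the compounds shown here, this step is modest, while a 13-fold higher number from compound 1 to compound 2 (1.11 log units; beyond the scatter) is large, but the two steps belong to different places, so the aromatic carbon and the saturated ring carbon each have only a single reading. The data shown offer no explanation for the shift with methoxy.

On these data alone, whether methoxy at this aromatic carbon and hydroxy on the saturated ring carbon combine in one compound remains open. Also open, as far as these compounds go, is how an amine, chlorine or a longer chain such as propylsulfanyl would read at the same aromatic carbon.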